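Amino in place of nitro on the anilino ring

The compounds below may be only part of what the source reports. "The series", "measured", "known", "first", "only" and "open" are said of these compounds alone.

Compound 2 `CNc1nc(Nc2ccc(C)c([N+](=O)[O-])c2)ncc1C(=O)Nc1cc(NC(=O)c2ccc3c(c2)OCCO3)ccc1C` gives 320 nM in a functional assay on K562 cells (Homo sapiens) for antiproliferative activity, read by CellTiter-Glo and CCK-8 assay, with a stated time of 72 h; a lower number here means a stronger inhibitor of growth, a higher number a weaker inhibitor of growth. Within the data shown here, compound 2 stands as the highest of the two numbers so far; the nearest is compound 1 `CNc1nc(Nc2ccc(C)c([N+](=O)[O-])c2)ncc1C(=O)Nc1cc(NC(=O)c2cccc(C(F)(F)F)c2)ccc1C`, which in this assay gives 52 nM; the only measured step, a 6.2-fold higher number from compound 1 to compound 2 (0.79 log units; beyond the scatter), concerns a different part of the molecule. Compound 3 `CNc1nc(Nc2ccc(C)c(N)c2)ncc1C(=O)Nc1cc(NC(=O)c2ccc3c(c2)OCCO3)ccc1C` differs from compound 2 in one place: amino in place of nitro on an aromatic carbon. Among the measured compounds shown here, no measured step touches this position, so nothing within these two compounds tells how large the change will be or which way it runs. The account therefore rests on a central guess near the number of compound 2 with a wide range. The expected step from compound 2 to compound 3 is a 1.6-fold higher number from compound 2 to compound 3 (0.19 log units; within the scatter). Compound 3 is thus estimated at 500 nM in this assay, with a range from 120 nM to 2500 nM.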

Compound 3, concentration for 50% growth inhibition: 320 nM
Compound 3: middle estimate off by 1.6-fold (0.19 log units), on the high side; measured number inside the range.
By their numbers in this assay, from the lowest: compound 1; then compounds 2 and 3 (each within the scatter of the next).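

In this assay, among these compounds, the first measured change on the anilino ring gives no change at the digits printed from compound 2 to compound 3 (within the scatter), so on this background the 4-methyl-3-nitrophenyl and 3-amino-4-methylphenyl groups cannot be told apart by growth inhibition. The other listed change, at the carbonyl end of the molecule, gives a 6.2-fold higher number from compound 1 to compound 2 (0.79 log units; beyond the scatter), so in this pair of steps the number moves with the change at that end and not with this one. Nothing given here explains why the swap of nitro for amino leaves the number in place.

Still open, on these data alone, is whether the same swap would also leave the number in place with the 3-(trifluoromethyl)phenyl group of compound 1. As far as these compounds go, it is also open how an acetamide, a carboxylic acid or a methoxy group on this aromatic carbon would compare with nitro and amino.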